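A few compounds are considered here, and "the series" means these few. Any claim that something is new, unique, unknown or untested is made for them only; others in the source may bear on it.

Measured compounds:
compound 1 `O=C1N=C(N2N=C(c3ccccc3)CC2c2ccccc2O)S/C1=C1/C(=O)Nc2ccccc21` — 4220 nM
compound 2 `O=C1N=C(N2N=C(c3ccccc3)CC2c2ccccc2O)S/C1=C1/C(=O)Nc2ccc(Br)cc21` — 460 nM
compound 3 `COc1ccc(C2=NN(C3=NC(=O)/C(=C4\C(=O)Nc5ccccc54)S3)C(c3ccc(OC)cc3)C2)cc1` — 100000 nM

In a functional assay on cells (Cancer cell lines, Homo sapiens) for cytotoxicity, read by sulforhodamine B assay, with a stated time of 48 h (on this read-out lower numbers stand for stronger inhibition of growth and higher numbers for weaker inhibition of growth), compound 1 gives 4220 nM and compound 2 gives 460 nM. The change between them is bromo in place of hydrogen on an aromatic carbon and it made the step of a 9.2-fold lower number from compound 1 to compound 2 (0.96 log units; beyond the scatter). Compound 3 gives 100000 nM in this assay, the highest number of the three measured compounds. The difference between the core of compound 1 and the core of compound 3 is not broken down here. Compound 4 `COc1ccc(C2=NN(C3=NC(=O)/C(=C4\C(=O)Nc5ccc(Br)cc54)S3)C(c3ccc(OC)cc3)C2)cc1` has not yet been measured; it differs from compound 3 by bromo in place of hydrogen on an aromatic carbon, the same change as that from compound 1 to compound 2, at a place described in the same words. Because of the step of a 9.2-fold lower number from compound 1 to compound 2 (0.96 log units; beyond the scatter), a lowering of a similar kind is expected for compound 4, though a single earlier example on a different core is a thin basis for the size of the effect. The expected step is a 6.7-fold lower number from compound 3 to compound 4 (0.82 log units; beyond the scatter). Compound 4 is therefore estimated at 15000 nM, with a likely range from 4000 nM to 60000 nM.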

Compound 4, concentration for total growth inhibition: 25300 nM
Compound 4: middle estimate off by 1.7-fold (0.23 log units), on the low side, within the range that was stated.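

In this assay, bromo in place of hydrogen on an aromatic carbon gave a 4.0-fold lower number from compound 3 to compound 4 (0.60 log units; beyond the scatter), so the number fell on this second core as it had on the first. Set side by side, the two steps point the same way and cannot be told apart in size: the same change on two cores in this assay, a 9.2-fold lower number (0.96 log units; beyond the scatter) from compound 1 to compound 2 and a 4.0-fold lower number (0.60 log units; beyond the scatter) from compound 3 to compound 4, 2.3-fold (0.37 log units) apart, within the scatter of two such steps This shows that, across these two cores, the change carried over in direction and, within the scatter, in size, but it rests on only two pairs and shows neither that the change would carry to any other core nor why it lowers the number.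

The compounds shown leave open whether chloro, fluoro or an amine on the same aromatic carbon would lower the number as bromo does, and whether bromo on another carbon of that ring would do the same. They also leave open which of the differences between the core of compound 1 and the core of compound 3 matters, since no pair shown separates those differences.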